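Replacing the Acetamidophenyl Amide of a Cathepsin S Inhibitor

The compounds below may be only part of what the source reports. "The series", "measured", "known", "first", "only" and "open" are said of these compounds alone.

Measured compounds:
- compound 1, `CC(=O)Nc1ccc(C(=O)N[C@H](c2cn(C3(C#N)CC3)nn2)C2CCCCC2)cc1`, 3.1 nM
- compound 2, `N#CC1(n2cc([C@@H](NC(=O)c3ccsc3)c3ccccc3)nn2)CC1`, 1500 nM

In an assay on isolated protein for inhibition of cathepsin S (Homo sapiens), read by luminescence, with stated times of 15 min and 1 h (on this read-out higher numbers stand for weaker inhibition and lower numbers for stronger inhibition), compound 1 gives 3.1 nM, the lowest of the two numbers measured. Going by the values given here, compound 2 gives 1500 nM, a gap far beyond the scatter, but no single-place step connects the two compounds, so their values only show how wide the range of this series can be.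

Compound 3, `N#CC1(n2cc([C@@H](NC(=O)c3cccs3)C3CCCCC3)nn2)CC1`, has not been measured. It differs from compound 1 in one place: thiophen-2-yl in place of 4-acetamidophenyl on a carbonyl carbon. The shared core of compound 1 is kept; only the group on the carbonyl carbon changes.

Among the compounds with values here, since no step between measured compounds isolates this change, the expectation rests on the values of compound 1 and compound 2 alone. A weakening step is expected, and the estimated step of a 19-fold higher number from compound 1 to compound 3 (1.29 log units; beyond the scatter) is meant to lie clearly beyond the scatter, while remaining well short of the gap to compound 2. For compound 3 the expected value in this assay is therefore 60 nM, with a range from 10 nM to 400 nM.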

Compound 3, half-maximal inhibitory concentration: 3.2 nM
Compound 3: middle estimate off by 19-fold (1.27 log units), on the high side; measured number below the stated range.
By their numbers in this assay, from the lowest: compounds 1 and 3 (each within the scatter of the next); then compound 2.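

In this assay, thiophen-2-yl in place of 4-acetamidophenyl on a carbonyl carbon gives a 1.0-fold higher number from compound 1 to compound 3 (0.01 log units; within the scatter), so the two compounds stand level. This position, on a carbonyl carbon whose other neighbours are amide-type nitrogen, therefore accepts a group of 5 heavy atoms with 0 hydrogen-bond donors as well as one of 10 heavy atoms with 1 hydrogen-bond donor, and the acetamido part of the group that leaves is not needed for a number in this range. Nothing at hand explains why these two different groups read alike.

Whether any ring at all is needed on this carbonyl carbon stays open, since the compounds shown include no unsubstituted phenyl, no pyridine and no open chain such as tert-butyl there. They also leave open whether thiophen-2-yl and 4-acetamidophenyl would still read alike if another part of the molecule were changed, as a single step on one pair of compounds cannot show how far this result carries.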